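A few compounds are considered here, and "the series" means these few. Any claim that something is new, unique, unknown or untested is made for them only; others in the source may bear on it.

Of the compounds shown here, three that share one core have been tested in an ADME assay on DU-145 cells (Homo sapiens) for cytotoxicity, read by MTT assay, with a stated time of 72 h; a higher number here means a weaker inhibitor of growth, a lower number a stronger inhibitor of growth. Compound 1 `O=C(O)C1C(C(=O)NCCCc2ccccc2)[C@H]2CC[C@@H]1O2` gives 10000 nM. Compound 2 `O=C(O)c1ccc(NC(=O)C2C(C(=O)O)[C@@H]3CC[C@H]2O3)cc1Cl` gives 10000 nM, and compound 3 `O=C(O)C1C(C(=O)Nc2ccc(Br)cc2)[C@H]2CC[C@@H]1O2` gives 10000 nM. At the digits recorded, compound 1 stands level with both of the others: its gap to compound 2 and its gap to compound 3 each lie within the scatter, so none of the three can be called stronger or weaker than another. All three sit at the same round figure, and they differ only in the group carried beyond the amide-type nitrogen.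

Compound 4 `CCCCCCCCNC(=O)C1C(C(=O)O)[C@@H]2CC[C@H]1O2` has not yet been measured in this assay. It differs from compound 1 in one place: pentyl in place of phenyl on a saturated chain carbon, three bonds along the chain from an amide-type nitrogen. Among the compounds with values here, no step between two measured compounds is available to show what such a change does here; the only guide is that three different groups at that position all return the same figure. On that basis the expected step is small, in no set direction, and within the scatter: no change at the digits printed from compound 1 to compound 4 (within the scatter). Compound 4 is therefore expected to give about 10000 nM, with a range from 4000 nM to 25000 nM.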

Compound 4, concentration for 50% growth inhibition: 10000 nM
Compound 4: middle estimate and measured number agree at the digits printed; the measured number falls inside the stated range.
By their numbers in this assay, from the lowest: compounds 1, 2, 3 and 4 (each within the scatter of the next).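

In this assay, within the data shown here, putting pentyl in place of phenyl on a saturated chain carbon, three bonds along the chain from an amide-type nitrogen, gives no change at the digits printed from compound 1 to compound 4 (within the scatter), and this is the first step here between measured compounds that differ in one place. It shows that at this position the six-membered aromatic ring of compound 1 can give way to an open chain with no ring at all, and no difference appears in this read-out. Nothing measured here bears on why the figure stays the same.

The compounds shown leave open whether any group at this place can separate itself from the others, for example an amine or a hydroxyl at the end of the chain, or a much longer chain. All four compounds also carry the same carboxylic acid on the shared core, so they cannot say what a methyl ester in its place would do.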